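This account rests on a few compounds, and the source may have more. Where it says the series, first, only, none or still open, it means among the compounds named here.

Of the compounds shown here, three have been measured so far. Compound 1 `COC1CCN(CC(=O)N2CCN(c3sc(C(F)(F)F)nc3-c3nc4ccccc4[nH]3)C[C@H]2C)C1` gives 42 nM in a functional assay on CHO-K1 cells for antagonist activity at C-X-C chemokine receptor type 3 (Homo sapiens), read by FLIPR, with a stated time of 10 min, in the presence of a further agent that is not named here; a higher number here means a weaker inhibitor, a lower number a stronger inhibitor. Compound 2 `Cc1nc(C)n(CC(=O)N2CCN(c3sc(C(F)(F)F)nc3-c3nc4c(F)cccc4[nH]3)C[C@H]2C)n1` gives 3.1 nM in this assay, and compound 3 `Cc1nc(C)n(CC(=O)N2CCN(c3sc(C(F)(F)F)nc3-c3nc4ccc(C5CCOCC5)cc4[nH]3)C[C@H]2C)n1` gives 3.3 nM in this assay. Compound 3 therefore sits with the second highest of the three numbers, but its nearest neighbour is compound 2, whose number is so close that the two cannot be told apart within the usual scatter, while compound 1 stands far off with a clearly higher number.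

The step now goes from compound 3 to compound 4 `Cc1nc(C)n(CC(=O)N2CCN(c3sc(C(F)(F)F)nc3-c3nc4ccccc4[nH]3)C[C@H]2C)n1`, which has not yet been measured. The change is a single one: hydrogen in place of oxan-4-yl on an aromatic carbon. Among the compounds with values here, no comparable step between two measured compounds is available, so the size of this change has to be judged without a direct precedent.

Compound 2 and compound 3 both give low numbers in this assay, so removing the oxan-4-yl group is not expected to move the number far; a small step toward a higher number, close to or just beyond the scatter, is the expectation for compound 4, namely a 1.8-fold higher number from compound 3 to compound 4 (0.26 log units; within the scatter). Compound 4 is thus estimated at 6 nM, within a range from 2 nM to 18 nM.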

Compound 4, half-maximal inhibitory concentration in the C-X-C chemokine receptor type 3 assay: 3.2 nM
For compound 4 the middle estimate is 1.9-fold (0.27 log units) above the measured one, within the range that was stated.
By their numbers in the C-X-C chemokine receptor type 3 assay, from the lowest: compounds 2, 4 and 3 (each within the scatter of the next); then compound 1.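

In the C-X-C chemokine receptor type 3 assay, hydrogen in place of oxan-4-yl on an aromatic carbon gives a 1.0-fold lower number from compound 3 to compound 4 (0.01 log units; within the scatter), so oxan-4-yl can leave this position with no readable change in the number. Hydrogen in place of fluoro on an aromatic carbon gives a 1.0-fold higher number from compound 2 to compound 4 (0.01 log units; within the scatter), so compound 4, with neither substituent on the six-membered aromatic ring, cannot be told apart from compound 2 or compound 3. The other end of the molecule now gets its first single-change comparison: 3,5-dimethyl-1H-1,2,4-triazol-1-yl in place of 3-methoxypyrrolidin-1-yl on a saturated chain carbon bound to a carbonyl carbon gives a 13-fold lower number from compound 1 to compound 4 (1.12 log units; beyond the scatter), a large step that compound 1 could not show against compound 2 or compound 3, which each differ from it in more than one place.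

In a physicochemical assay for solubility, in simulated intestinal fluid (on this read-out lower numbers stand for lower solubility and higher numbers for higher solubility), compound 3 gives > 1000 ug/mL as a limit of the assay. In the physicochemical assay compound 4 gives > 850 ug/mL as a limit of the assay. The step between these two compounds cannot be read. As far as these compounds go, it remains open whether a carboxylic acid or an amine on that aromatic carbon would leave the number in the C-X-C chemokine receptor type 3 assay just as unmoved, or which other groups on the saturated chain carbon would match the dimethyltriazole.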